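Thioether-linked benzamides: growth inhibition at one concentration

The source may report more compounds than this note shows. Statements on the series, on what has been measured and on what is new or still open speak of the compounds shown alone.

Measured so far:
compound 1 `COc1ccc(SCc2ccc(/C=C/C(=O)Nc3ccccc3N)cc2)cc1OC` — 14.3%
compound 2 `Nc1ccccc1NC(=O)c1ccc(CSc2ccc(Br)cc2)cc1` — 10%
compound 3 `COC(=O)c1ccccc1SCc1ccc(C(=O)Nc2ccccc2N)cc1` — 18%

In a functional assay on SMMC-7721 cells (Homo sapiens) for inhibition, read by CCK-8 assay, with a stated time of 72 h, tested at 2 uM (on this read-out lower numbers stand for less inhibition of growth and higher numbers for more inhibition of growth at the one concentration tested), compound 1 gives 14.3%. On the three numbers this is the second highest, yet its gaps to compound 3 and to compound 2 both lie within the scatter, so the three compounds cannot be ordered on these data. Compound 4 `CC(C)(C)c1ccc(SCc2ccc(/C=C/C(=O)Nc3ccccc3N)cc2)cc1` differs from compound 1 in one place: 4-(tert-butyl)phenyl in place of 3,4-dimethoxyphenyl on a sulfur. Going by the values given here, no measured pair differs only in this way, so the effect of this change is unknown here. The step of a number 0.7 percentage points higher from compound 1 to compound 4 (within the scatter) is expected to stay within the scatter, in either direction. Compound 4 is estimated at 15%, with a range from 4% to 28%.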

Compound 4, percent growth inhibition at one concentration: 18.3%
Beside the measured number, compound 4's estimate is 3.3 percentage points below it; measured number inside the range.
By their numbers in this assay, from the lowest: compounds 2, 1, 3 and 4 (each within the scatter of the next).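

In this assay, going by these compounds alone, the swap to 4-(tert-butyl)phenyl in place of 3,4-dimethoxyphenyl on a sulfur gives a number 4 percentage points higher from compound 1 to compound 4 (within the scatter) and is the first comparison that differs in one place. On this sulfur, a ring with 0 hydrogen-bond acceptors thus reads the same, within the scatter, as one with 2 hydrogen-bond acceptors. No evidence bears on the reason for this result. Open, going by these compounds, is whether a phenyl ring carrying an amine or a carboxylic acid on this sulfur, or a longer chain in place of the ring, would move growth inhibition beyond the scatter.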